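The compounds below may be only part of what the source reports. "The series", "measured", "known", "first", "only" and "open" are said of these compounds alone.

Working notes on the oxindole series.

Compound 3 `COc1c(/C=C2/C(=O)Nc3ccc(Cl)cc32)c2ccccc2n1-c1ccccc1` is the point of departure. In a functional assay on cells (Cancer cell lines, Homo sapiens) for cytotoxicity, with a stated time of 48 h (a higher number here means a weaker inhibitor of growth, a lower number a stronger inhibitor of growth), compound 3 gives 19100 nM, the second highest of the three numbers recorded so far. Its nearest neighbour is compound 1 `COc1cc2c(/C=C3/C(=O)Nc4ccc(O)cc43)c(Cl)n(Cc3cc(OC)c(OC)c(OC)c3)c2cc1C`, which in this assay gives 34700 nM, a gap that lies within the scatter of the method; the furthest is compound 2 `COc1c(/C=C2/C(=O)Nc3ccccc32)c2ccccc2n1-c1ccccc1`, which gives 8510 nM. Within the data shown here, the only measured step that touches compound 3 is a 2.2-fold higher number from compound 2 to compound 3 (0.35 log units; beyond the scatter), that is, chloro in place of hydrogen on an aromatic carbon of the shared core.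

Compound 4 `COc1ccc2c(c1)/C(=C\c1c(OC)n(-c3ccccc3)c3ccccc13)C(=O)N2` differs from compound 3 by methoxy in place of chloro on an aromatic carbon. Among the measured compounds shown here, no measured pair shows methoxy entering at this place, so the one step that bears on the change is the chloro-for-hydrogen step above, read in reverse: removing the chloro would be expected to bring the number back toward that of compound 2, while the incoming methoxy is untested. The two effects are therefore uncertain in sign, and a step no larger than modest, if any beyond the scatter, is expected for a 1.7-fold lower number from compound 3 to compound 4 (0.24 log units; within the scatter). Compound 4 is estimated at 11000 nM, with a plausible range from 4000 nM to 30000 nM.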

Compound 4, concentration for total growth inhibition: 9550 nM
Compound 4: the middle estimate sits 1.2-fold (0.06 log units) above what was measured; the range from low to high includes it.
By their numbers in this assay, from the lowest: compounds 2, 4, 3 and 1 (each within the scatter of the next, the first and the last beyond it).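

Among these compounds, compound 4 gives the first reading of methoxy on this aromatic carbon, and in this assay putting methoxy in place of hydrogen gives a 1.1-fold higher number from compound 2 to compound 4 (0.05 log units; within the scatter), so at this place the group brings no change that can be told from the scatter. Methoxy in place of chloro gives a 2.0-fold lower number from compound 3 to compound 4 (0.30 log units; within the scatter), which also lies within the scatter, so compound 3 and compound 4 cannot be put in order on these numbers. Of the three steps among hydrogen, chloro and methoxy at this place, only the chloro-for-hydrogen step stands beyond the scatter and it is modest, while nothing available here bears on why these numbers fall as they do.

Still open, as far as these compounds go, is whether an amine or a carboxylic acid on this same aromatic carbon would move the number clearly in either direction, or whether this place stays as flat as these three groups suggest. Among the compounds shown here, also open is whether methoxy would behave the same way on the core of compound 1, which differs from these compounds in more than one place and so gives no step here.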